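The source may report more compounds than this note shows. Statements on the series, on what has been measured and on what is new or still open speak of the compounds shown alone.

The measured compounds, with their values in a functional assay on A549 cells (Homo sapiens) for cytotoxicity, read by MTT assay, with a stated time of 48 h; on this read-out lower numbers stand for stronger inhibition and higher numbers for weaker inhibition:
Compound 1, `COc1cc(C(=O)NC2CCN(C)CC2)ccc1Nc1ncc(Br)c(NC2CCCC2)n1`, gives 2500 nM.
Compound 2, `CN1CCN(c2ccc(Nc3ncc(F)c(NC4CCCC4)n3)cc2)CC1`, gives 37200 nM.
Compound 3, `COc1cc(C(=O)NC2CCN(C)CC2)ccc1Nc1ncc(F)c(NC2CCCC2)n1`, gives 2100 nM.

For the measured compounds named here, compound 3 has the lowest number of the three in this assay, but it cannot be set apart from compound 1: the only single-place step measured, a 1.2-fold lower number from compound 1 to compound 3 (0.08 log units; within the scatter), lies within the scatter, so the two compounds are indistinguishable. Compound 2, which lacks both the methoxy and the (1-methylpiperidin-4-yl)carbamoyl group of compound 3, stands far off with a much higher number, beyond the scatter.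

Compound 4, `CN1CCC(NC(=O)c2ccc(Nc3ncc(F)c(NC4CCCC4)n3)cc2)CC1`, has not yet been measured. It differs from compound 3 in one place: hydrogen in place of methoxy on an aromatic carbon. Going by the values given here, no measured step touches the methoxy. Among the compounds with values here, the one step measured concerns a halogen exchange, and its size, a 1.2-fold lower number from compound 1 to compound 3 (0.08 log units; within the scatter), was within the scatter, so it offers no guidance here. Compound 2 also lacks the methoxy, but it carries a different group as well, so its value cannot be traced to the methoxy alone.

Within the data shown here, with no step bearing on this change, compound 4 is estimated to give 4500 nM in this assay, with an expected range from 1500 nM to 15000 nM. The estimated step is a 2.1-fold higher number from compound 3 to compound 4 (0.33 log units; beyond the scatter), a modest weakening at most, with a wide range reflecting the absence of direct evidence.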

Compound 4, half-maximal inhibitory concentration: 10300 nM
Compound 4: the middle estimate sits 2.3-fold (0.36 log units) below what was measured; the range from low to high includes it.
By their numbers in this assay, from the lowest: compounds 3 and 1 (each within the scatter of the next); then compound 4; then compound 2.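

For the compounds shown here, the methoxy turns out to matter at this place, ortho to a large group and meta to the (1-methylpiperidin-4-yl)carbamoyl group: in this assay, removing it gives a 4.9-fold higher number from compound 3 to compound 4 (0.69 log units; beyond the scatter), the first measured change on this ring that lies beyond the scatter. The step of a 3.6-fold lower number from compound 2 to compound 4 (0.56 log units; beyond the scatter) shows that, even with hydrogen at this place, the (1-methylpiperidin-4-yl)carbamoyl group gives a lower number than the 4-methylpiperazin-1-yl group. No measurement in hand explains why hydrogen in place of methoxy raises the number in this cell assay.

The compounds shown leave open whether an ethoxy group, a hydroxyl group or a chlorine atom at this place would keep the number of compound 3 or move it towards that of compound 4. They also leave open whether the methoxy step would keep its size with the bromo of compound 1 in place of the fluoro, or with the 4-methylpiperazin-1-yl group of compound 2 in place of the (1-methylpiperidin-4-yl)carbamoyl group.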